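The source may hold more compounds than are shown below. What is called first, only, known or untested is meant among the compounds shown, and "the series" means these compounds.

Measured compounds: compound 1 `CCCCCCCCCCCC[C@@H](O)[C@H]1CC[C@H]([C@H](O)CCCCCCCCCCNC(=O)c2ccco2)O1` gives 100000 nM in a functional assay (RXF 631 cells, Homo sapiens) for inhibition, read by colorimetric assay and sulforhodamine B assay, with a stated time of 48 h; a lower number here means a stronger inhibitor of growth, a higher number a weaker inhibitor of growth; compound 2 `CCCCCCCCCCCC[C@@H](O)[C@H]1CC[C@H]([C@H](O)CCCCCCCCCCNC(=O)c2cncs2)O1` gives 100000 nM in this assay.

Compound 2 thus stands level with compound 1 on the shared core, and the step of no change at the digits printed from compound 1 to compound 2 (within the scatter) shows no change within the scatter. Compound 3 `CCCCCCCCCCCC[C@@H](O)[C@H]1CC[C@H]([C@H](O)CCCCCCCCCCNC(=O)c2ccnn2C)O1` differs from compound 2 by one change: 1-methyl-1H-pyrazol-5-yl in place of 1,3-thiazol-5-yl on a carbonyl carbon. Going by the values given here, the only step that bears on it, no change at the digits printed from compound 1 to compound 2 (within the scatter), swapped one five-membered aromatic ring for another with no effect, so a step of size no change at the digits printed from compound 2 to compound 3 (within the scatter) is expected, that is none beyond the scatter. Compound 3 is estimated at 100000 nM in this assay, within 40000 nM to 100000 nM.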

Compound 3, concentration for 50% growth inhibition: 100000 nM
Compound 3: middle estimate and measured number agree at the digits printed; measured number inside the range.
By their numbers in this assay, from the lowest: compounds 1, 2 and 3 (each within the scatter of the next).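

On the carbonyl carbon of the amide, 1-methyl-1H-pyrazol-5-yl, a ring that carries a methyl group, gives the same reading in this assay as 1,3-thiazol-5-yl (no change at the digits printed from compound 2 to compound 3 (within the scatter)) and furan-2-yl (no change at the digits printed from compound 1 to compound 3 (within the scatter)). Across these three five-membered aromatic rings, the choice of ring at this position makes no visible difference to growth inhibition. No evidence is available to explain this result. Still open, going by these compounds, is whether a phenyl ring, an amine or a carboxylic acid at this position, or a shorter chain leading to the amide, would give a lower number.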